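Replacing the aryl group on the urea of compound 1

The source may report more compounds than this note shows. Statements on the series, on what has been measured and on what is new or still open speak of the compounds shown alone.

Two compounds have been measured in a functional assay on MCF7 cells (Homo sapiens) for inhibition, read by MTT assay, with a stated time of 72 h; a lower number here means a stronger inhibitor, a higher number a weaker inhibitor:
compound 1 `COc1cc(NC(C)CCCNC(=O)Nc2cccc(Cl)c2)c2ncccc2c1` gives 11000 nM
compound 2 `COc1cc(NC(C)CCCNC(=O)NNC(=O)Nc2ccc(F)cc2)c2ncccc2c1` gives 310 nM

Among the compounds with values here, compound 1 stands highest of these two numbers; its only neighbour is compound 2, reached by the step of a 35-fold lower number from compound 1 to compound 2 (1.55 log units; beyond the scatter). Compound 3 `COc1cc(NC(C)CCCNC(=O)Nc2ccc(O)cc2)c2ncccc2c1` is not yet measured. It differs from compound 1 in one place: 4-hydroxyphenyl in place of 3-chlorophenyl on an amide-type nitrogen. The measured step from compound 1 to compound 2 touches the same amide-type nitrogen, but it exchanges the aryl group for a ((4-fluorophenyl)carbamoyl)amino group, a different change, so it bears only loosely on the present one. Within the data shown here, no measured step exchanges one aryl group for another on this nitrogen. A change of moderate size is therefore expected, most likely toward a somewhat lower number, as the step of a 1.8-fold lower number from compound 1 to compound 3 (0.26 log units; within the scatter). Compound 3 is thus estimated at 6000 nM, in the range 1500 nM to 25000 nM.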

Compound 3, half-maximal inhibitory concentration: 5200 nM
The estimate for compound 3 lay 1.2-fold (0.06 log units) above the measured number; the measured number falls inside the stated range.
By their numbers in this assay, from the lowest: compound 2; then compound 3; then compound 1.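

In this assay, within the data shown here, exchanging one aryl group for another on the amide-type nitrogen gives a small but real shift (a 2.1-fold lower number from compound 1 to compound 3 (0.33 log units; beyond the scatter)), the first view of a change confined to the aryl group itself. This shift remains small beside the gap to the ((4-fluorophenyl)carbamoyl)amino group (a 17-fold higher number from compound 2 to compound 3 (1.22 log units; beyond the scatter)), so among these compounds the larger effect comes with that group and not with a different aryl group on the nitrogen. Nothing available explains either step.

Because 4-hydroxyphenyl differs from 3-chlorophenyl in both its substituent and where that substituent sits, the compounds shown cannot separate these two features. They also leave open whether a 4-fluorophenyl group placed directly on this nitrogen, or a 4-aminophenyl group, would behave like the aryl groups or like compound 2.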